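This account rests on a few compounds, and the source may have more. Where it says the series, first, only, none or still open, it means among the compounds named here.

Compound 1 `CNC(=O)c1cc(C(=O)N[C@H]2[C@@H]3C[C@@H](OC)C[C@@H]32)n([C@@H](C)c2ccccc2)n1` gives 2.7 in a physicochemical assay for lipophilicity; on this read-out lower numbers stand for lower lipophilicity and higher numbers for higher lipophilicity. Compound 2 `CNC(=O)c1cc(C(=O)N[C@H]2[C@@H]3COC[C@@H]32)c([C@@H](C)c2ccccc2)o1` gives 4.1. Compound 3 `CNC(=O)c1cc(C(=O)N[C@H]2[C@@H]3C[C@@H](O)C[C@@H]32)c([C@@H](C)c2ccccc2)o1` gives 2.8.

Compound 1 has the lowest of these three numbers: compound 3 sits within the scatter of it, while compound 2 lies well above it. Compound 4 `CNC(=O)c1cc(C(=O)NC2CC2)n([C@@H](C)c2ccccc2)n1` differs from compound 1 in one place: a group of 3 heavy atoms (3 carbon; one three-membered non-aromatic ring of carbon only) in place of a group of 8 heavy atoms (7 carbon, 1 oxygen; one three-membered non-aromatic ring of carbon only, one five-membered non-aromatic ring of carbon only), on an amide-type nitrogen. Going by the values given here, the only measured step, a number 1.30 log units lower from compound 2 to compound 3 (beyond the scatter), concerns a different change on the same amide-type nitrogen and does not cover this one, so no step here speaks directly to the exchange. With an oxygen leaving and the group shrinking, a change of roughly a number 0.20 log units lower from compound 1 to compound 4 (within the scatter) is expected, in no direction beyond the scatter. Compound 4 is therefore estimated at 2.5, between 1.9 and 3.1.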

Compound 4, distribution coefficient: 3.6
Compound 4: middle estimate off by 1.10 log units, on the low side; measured number outside the range, above it.
By their numbers in this assay, from the lowest: compounds 1 and 3 (each within the scatter of the next); then compound 4; then compound 2.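

In this assay cyclopropyl in place of the group of 8 heavy atoms on the amide-type nitrogen gives a number 0.90 log units higher from compound 1 to compound 4 (beyond the scatter), so the read-out at this position responds to an exchange that removes the oxygen and shrinks the group. The earlier compounds shown here held only a step between two larger groups and did not show what a group as small as cyclopropyl does here. Nothing shown accounts for the size or direction of this step.

From the compounds shown here alone, it remains open where a chain carrying an amine or a carboxylic acid on this nitrogen would fall. Going by these compounds, it is also open whether cyclopropyl would give a step of similar size on the core of compound 3.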